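Swapping the thiocarbonyl group for bromine in compound 1

The compounds below may be only part of what the source reports. "The series", "measured", "known", "first", "only" and "open" are said of these compounds alone.

Compound 1 `COc1ccc(-c2coc3cc(OCCCSC(=S)N4CCOCC4)ccc3c2=O)cc1` is tested in a functional assay on MGC-803 cells (Homo sapiens) for inhibition, read by MTT assay, with a stated time of 48 h (on this read-out higher numbers stand for weaker inhibition and lower numbers for stronger inhibition), where compound 1 gives 49600 nM, the highest of the three numbers measured. Among the compounds with values here, compound 3 `COc1ccc(-c2coc3cc(OCCCSC(=S)N4CCN(C(C)=O)CC4)ccc3c2=O)cc1` gives 39400 nM, and the change to it, a 1.3-fold lower number from compound 1 to compound 3 (0.10 log units; within the scatter), is the only single-place step recorded. Compound 2 `COc1ccc(-c2coc3cc(OCCSC(=S)N4CCN(C(=O)OC(C)(C)C)CC4)ccc3c2=O)cc1` gives 11600 nM, but it differs from compound 1 in two places, so its values show only a gap, not a step. Compound 4 `COc1ccc(-c2coc3cc(OCCCBr)ccc3c2=O)cc1` differs from compound 1 by one bromine atom in place of a group of 9 heavy atoms (5 carbon, 1 nitrogen, 1 oxygen, 2 sulfur; one six-membered non-aromatic ring with 2 hetero atoms), on a saturated chain carbon, three bonds along the chain from an oxygen on an aromatic ring. Within the data shown here, no measured step bears on this change, and the one recorded step stayed within the scatter, so compound 4 is expected to land near compound 1 or somewhat higher, as a 1.3-fold higher number from compound 1 to compound 4 (0.12 log units; within the scatter). The estimate for compound 4 is 65000 nM, within 20000 nM to 200000 nM.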

Compound 4, half-maximal inhibitory concentration: 64900 nM
For compound 4 the middle estimate is 1.0-fold (0.00 log units) above the measured one; measured number inside the range.
By their numbers in this assay, from the lowest: compound 2; then compounds 3, 1 and 4 (each within the scatter of the next).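

In this assay, one bromine atom can stand in for the entire group of 9 heavy atoms on this saturated chain carbon with little effect on the number: a 1.3-fold higher number from compound 1 to compound 4 (0.12 log units; within the scatter). Compound 1 and compound 4 therefore cannot be told apart here, even though compound 4 lacks the six-membered ring and both sulfur atoms. Nothing available explains this result. Still open, going by these compounds, is whether an amine or a carboxylic acid on this carbon would move the number beyond the scatter. A longer chain carrying the bromine is equally untested in the compounds shown.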